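This account rests on a few compounds, and the source may have more. Where it says the series, first, only, none or still open, it means among the compounds named here.

Measured in a functional assay on MCF7 cells (Homo sapiens) for antiproliferative activity; on this read-out lower numbers stand for stronger inhibition and higher numbers for weaker inhibition:
- compound 1 `CCCNCCCOc1ccc2cc(NC(=O)c3ccc(O)c(CC=C(C)C)c3)c(=O)oc2c1C`: 980 nM
- compound 2 `CC(C)=CCc1cc(C(=O)Nc2cc3ccc(OCCCNC(C)(C)C)c(C)c3oc2=O)ccc1O`: 950 nM

Among the compounds with values here, compound 2 stands level with compound 1, the only other compound measured, and the two cannot be told apart on these numbers. The next structure is compound 3 `CC(C)=CCc1cc(C(=O)Nc2cc3ccc(OCCCNC4CCCCC4)c(C)c3oc2=O)ccc1O`, which carries cyclohexyl in place of tert-butyl on an amine nitrogen. Within the data shown here, one measured step bears on this change, at the same amine nitrogen, with tert-butyl in place of propyl: a 1.0-fold lower number from compound 1 to compound 2 (0.01 log units; within the scatter). Among the measured compounds shown here, that single step gives no sign that this assay responds to the group at this nitrogen, although no compound with a ring there has been measured. No shift beyond the scatter is therefore expected, in either direction. The expected step is a 1.1-fold lower number from compound 2 to compound 3 (0.02 log units; within the scatter). Compound 3 is estimated at 900 nM, with an expected range of 400 nM to 2000 nM.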

Compound 3, half-maximal inhibitory concentration: 1070 nM
Estimate against measurement, compound 3: 1.2-fold (0.08 log units) below; measured number inside the range.
By their numbers in this assay, from the lowest: compounds 2, 1 and 3 (each within the scatter of the next).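

In this assay, the first ring at this amine nitrogen leaves the number within the scatter of both earlier compounds: cyclohexyl gives a 1.1-fold higher number from compound 2 to compound 3 (0.05 log units; within the scatter), and against propyl it gives a 1.1-fold higher number from compound 1 to compound 3 (0.04 log units; within the scatter). The earlier pair compared only groups without a ring, so the flat response at this position now also covers a six-membered non-aromatic ring of carbon only, and compounds 1, 2 and 3 cannot be told apart. Nothing available explains this flat response.

Going by these compounds, all three groups on this nitrogen are built of carbon only, so it remains open whether a phenyl ring, a hydroxyethyl group or a carboxylic acid there would shift the number beyond the scatter. The rest of the structure is the same in all three compounds, so they say nothing about changes to the chain or the shared core.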